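The source may hold more compounds than are shown below. What is called first, only, known or untested is meant among the compounds shown, and "the series" means these compounds.

Of the compounds shown here, three built on one shared core have been measured in an assay on isolated protein (strain albino) for inhibition of Voltage-dependent L-type calcium channel subunit alpha-1C (Cavia porcellus); on this read-out lower numbers stand for stronger inhibition and higher numbers for weaker inhibition. Compound 1 `CCOC(=O)C1=C(C)NC(C)=C(C(=O)OCC)C1c1ccc(-c2cc(=O)cc(-c3ccccc3)o2)cc1` gives 12200 nM. Compound 2 `CCOC(=O)C1=C(C)NC(C)=C(C(=O)OCC)C1c1ccc(-c2cc(=O)cc(C)o2)cc1` gives 2140 nM, the lowest of the three numbers. Compound 3 `CCOC(=O)C1=C(C)NC(C)=C(C(=O)OCC)C1c1cc(=O)cc(C)o1`, a smaller variant, gives 35900 nM. For the measured compounds named here, the only step between compounds that differ in a single place is a 5.7-fold lower number from compound 1 to compound 2 (0.76 log units; beyond the scatter), where methyl takes the place of phenyl on an aromatic carbon. Compound 2 thus stands lowest, with compound 1 nearest to it and compound 3 furthest away.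

Compound 4 `CCOC(=O)C1=C(C)NC(C)=C(C(=O)OC)C1c1ccc(-c2cc(=O)cc(C)o2)cc1` differs from compound 2 only in hydrogen in place of methyl on a saturated chain carbon bound to an oxygen next to a carbonyl group; read one bond further out, this is ethoxycarbonyl becoming methoxycarbonyl on one of the two ester groups. Going by the values given here, no measured step touches an ester group: the single known step, from compound 1 to compound 2, altered a substituent on the distant side ring, so it gives no guidance on this change. With no comparison of this kind available, the expectation for compound 4 is a step of a 1.0-fold higher number from compound 2 to compound 4 (0.01 log units; within the scatter) in this assay, meaning no change beyond the usual scatter. Compound 4 is therefore estimated at 2200 nM, with a range from 700 nM to 7000 nM.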

Compound 4, half-maximal inhibitory concentration: 86100 nM
Compound 4: the middle estimate sits 39-fold (1.59 log units) below what was measured; the whole stated range lies below it.
By their numbers in this assay, from the lowest: compound 2; then compound 1; then compound 3; then compound 4.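

Swapping ethoxycarbonyl for methoxycarbonyl on one of the two ester groups removes only a methyl, yet in this assay it produces a 40-fold higher number from compound 2 to compound 4 (1.60 log units; beyond the scatter), a large step. For the compounds shown here, until now, the only readable change was on the distant side ring, where the modest step was a 5.7-fold lower number from compound 1 to compound 2 (0.76 log units; beyond the scatter); the new result shows that this ester position also matters, and that here a very small edit can outweigh that change. The direction also matters: at this position, the shorter ethyl-to-methyl form gives the higher number, which on this read-out means weaker inhibition, but nothing measured here explains why so small a change has so large an effect.

On these data alone, with only ethoxycarbonyl and methoxycarbonyl to compare at this position, it remains open whether a longer chain such as propoxycarbonyl would lower the number further, or whether ethoxycarbonyl is already the best fit. As far as these compounds go, it is also open how a carboxylic acid or an amide would behave in this place, and whether the same ethyl-to-methyl change on the second ester group would cost as much.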